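The source may report more compounds than this note shows. Statements on the series, on what has been measured and on what is new or still open speak of the compounds shown alone.

Measured in an ADME assay on RAW264.7 cells (Mus musculus) for cytotoxicity, read by MTT assay; on this read-out lower numbers stand for stronger inhibition and higher numbers for weaker inhibition:
- compound 1 `O=C(/C=C/C=C/c1ccccc1)c1cc(Br)ccc1O`: "not determined" (no result reported)
- compound 2 `Cc1ccc(C(=O)/C=C/C=C/c2ccccc2)s1`: > 100000 nM
- compound 3 `COc1ccc(/C=C/C=C/C(=O)c2ccc(C)s2)cc1`: "not determined" (no result reported)

Compound 3 has no number to stand on, since its entry reads "not determined" (no result reported). Among the measured compounds shown here, the only reading nearby belongs to compound 2, whose > 100000 nM is a limit of the assay and not a number.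

Compound 4 `COc1ccc(/C=C/C=C/C(=O)c2ccco2)cc1` is still unmeasured. The change furan-2-yl in place of 5-methylthiophen-2-yl on a carbonyl carbon swaps one five-membered aromatic ring for another, with furan-2-yl in place of 5-methylthiophen-2-yl on a carbonyl carbon. For the measured compounds named here, no measured step gives this swap a size, so no shift beyond the usual scatter is expected in this assay, and the expectation leans on compound 2 with its limit of > 100000 nM. For compound 4 the estimated value is 80000 nM, with an expected range from 25000 nM to 200000 nM.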

Compound 4, half-maximal inhibitory concentration: 76600 nM
Estimate against measurement, compound 4: 1.0-fold (0.02 log units) above; the range from low to high includes it.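

Among the compounds shown here, compound 3 reads "not determined" (no result reported) in this assay, so no step from it to compound 4 can be read. As far as these compounds go, what furan-2-yl in place of 5-methylthiophen-2-yl on a carbonyl carbon does to the value in this assay stays open.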